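The source may report more compounds than this note shows. Statements on the series, on what has been measured and on what is new or still open speak of the compounds shown alone.

In a functional assay on A2780 cells (Homo sapiens) for inhibition (a lower number here means a stronger inhibitor, a higher number a weaker inhibitor), compound 1 `CCNC(=O)c1noc(-c2cc(C(C)C)c(O)cc2O)c1-c1cc(C(=O)O)no1` gives 20000 nM and compound 2 `CCNC(=O)c1noc(-c2cc(C(C)C)c(O)cc2O)c1-c1ccn(CC)n1` gives 13 nM, so compound 2 holds the lower of the two numbers and is the stronger inhibitor of the pair. Compound 3 `CCNC(=O)c1noc(-c2cc(C(C)C)c(O)cc2O)c1-c1ccn(C(C)C)n1` differs from compound 2 in one place, methyl in place of hydrogen on a saturated chain carbon bound to an aromatic nitrogen and a saturated chain carbon, which turns ethyl to isopropyl. Within the data shown here, only one measured step bears on this, a 1500-fold lower number from compound 1 to compound 2 (3.19 log units; beyond the scatter). That step exchanged a whole ring group, so it says little about adding a single methyl to the ethyl of compound 2. As far as these compounds go, no step beyond the scatter is therefore expected in this assay, and the direction stays open. The expected result is a 1.2-fold higher number from compound 2 to compound 3 (0.09 log units; within the scatter). Compound 3 is estimated at 16 nM, with an expected range from 5 nM to 50 nM.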

Compound 3, half-maximal inhibitory concentration: 45 nM
Compound 3: middle estimate off by 2.8-fold (0.45 log units), on the low side, and the stated range covers the measured number.
By their numbers in this assay, from the lowest: compound 2; then compound 3; then compound 1.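

Adding a single methyl to the saturated chain carbon bound to an aromatic nitrogen, which turns ethyl to isopropyl, gives in this assay a 3.5-fold higher number from compound 2 to compound 3 (0.54 log units; beyond the scatter) and so shows that this position responds to even a one-carbon change, with ethyl the better of the two groups. The isopropyl compound still keeps most of the advantage over the carboxylic acid compound, with a 440-fold lower number from compound 1 to compound 3 (2.65 log units; beyond the scatter) for 1-isopropyl-1H-pyrazol-3-yl in place of 3-carboxy-1,2-oxazol-5-yl, so the exchange of the whole ring group outweighs the added methyl by far. Nothing measured here explains why the added methyl gives the higher number.

Only ethyl and isopropyl are shown on this nitrogen. As far as these compounds go, how a smaller methyl, a longer propyl chain or a chain ending in an amine would fall in this assay remains open.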